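The compounds below may be only part of what the source reports. "The series", "measured", "known", "first", "only" and "open" are said of these compounds alone.

Compound 1 `O=[N+]([O-])c1cccc(/N=N/N2CCCCC2)c1` in an ADME assay on MT4 cells (Homo sapiens) for cytotoxicity, read by MTT assay, with a stated time of 96 h; a lower number here means that less compound is tolerated, a higher number that more compound is tolerated: compound 1 gives > 100000 nM, which is a limit of this assay and not a number.
Compound 2 `CN(C)CCCN(/N=N/c1ccccc1)c1cccc(C(F)(F)F)c1`: compound 2 gives 14000 nM in this assay.
Compound 3 `CN(C)CCCNc1ccc(/N=N/c2ccccc2)cc1`: compound 3 gives 17000 nM in this assay.

Among the compounds with values here, of the three measured compounds, compound 1 is the one whose value in this assay is a limit only (the limit of > 100000 nM in this assay, at which 1 of the 3 values shown sits). The values of compound 2 and compound 3 lie within the scatter of each other. Compound 4 `c1ccc(/N=N/N2CCCCC2)cc1` has not yet been measured in this assay; it differs from compound 1 by hydrogen in place of nitro on an aromatic carbon. Within the data shown here, no measured pair shows this change, so the expected step from compound 1 to compound 4 in this assay is an at least 1.1-fold lower number from compound 1 to compound 4 (0.04 log units; that floor lies within the scatter), that is, none beyond the scatter. Compound 4 is therefore expected to give about 90000 nM in this assay, with a range from 35000 nM to 200000 nM.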

Compound 4, half-maximal cytotoxic concentration: > 100000 nM
Compound 4 gave a limit, no number; the forecaster's own chance of this, stated with the estimate: 50%; at least 1.1-fold (0.04 log units) between middle value and limit.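

No step from compound 1 to compound 4 can be read in this assay, because both results are limits and not numbers: the limit of > 100000 nM in this assay, at which 2 of the 4 values shown sit.

The compounds shown leave open whether hydrogen in place of nitro on an aromatic carbon changes the number in this assay at all.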